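Trimming a side chain: compound 2 to compound 3

A few compounds are considered here, and "the series" means these few. Any claim that something is new, unique, unknown or untested is made for them only; others in the source may bear on it.

Measured so far in an ADME assay on Vero cells (Chlorocebus sabaeus) for cytotoxicity, read by MTT assay, with a stated time of 24 h (a lower number here means that less compound is tolerated, a higher number that more compound is tolerated), each value being a limit and not a number:
- Compound 1 `Nc1nc(N)c2cc(NCc3ccc4c(c3)OCCO4)ccc2n1` gives > 200000 nM (a limit)
- Compound 2 `CN(C)CCCOc1ccc(CNc2ccc3nc(N)nc(N)c3c2)cc1` gives > 200000 nM (a limit)

Compound 2 therefore has no exact position, and the data show only (the limit of > 200000 nM in this assay, at which 2 of the 2 values shown sit). Compound 3 `COc1ccc(CNc2ccc3nc(N)nc(N)c3c2)cc1` carries methoxy where compound 2 carries 3-(dimethylamino)propoxy (hydrogen in place of 2-(dimethylamino)ethyl on a saturated chain carbon bound to an oxygen on an aromatic ring). Going by the values given here, no measured step shows what such a change does in this assay, so no change beyond the usual scatter is expected. This expectation rests on compound 2 sharing the limit of > 200000 nM in this assay, at which 2 of the 2 values shown sit, with compound 1. The expected size is a number no higher from compound 2 to compound 3 (the limit leaves the size open) overall. Compound 3 is estimated at 200000 nM, within a range of 100000 nM to 400000 nM, and will probably be reported as a limit.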

Compound 3, half-maximal cytotoxic concentration: 147000 nM
Estimate against measurement, compound 3: 1.4-fold (0.13 log units) above; measured number inside the range.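

In this assay, going by these compounds alone, compound 3 gives the only exact number so far, 147000 nM. Trimming 3-(dimethylamino)propoxy to methoxy brings an at least 1.3-fold lower number from compound 2 to compound 3 (0.13 log units; that floor lies within the scatter), so this change shows no effect beyond the scatter. Its true size stays unknown because compound 2 is only a limit: the limit of > 200000 nM in this assay, at which 2 of the 3 values shown sit.

The compounds shown leave open whether the chain length or the dimethylamino end matters more to this number. A shorter 2-(dimethylamino)ethoxy chain, or a carboxylic acid at the end of the chain, could separate those two parts.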